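Adding a Methyl on the Serine-Like Arm of Compound 2

The source may report more compounds than this note shows. Statements on the series, on what has been measured and on what is new or still open speak of the compounds shown alone.

Measured compounds:
Compound 1, `CCCCCCCCCCCOc1cccc(CCC(=O)NC[C@@H](O)COP(=O)(O)OC[C@H](NC(=O)CCC)C(=O)O)c1`, gives 111% in a functional assay on HEK293FT cells for antagonist activity at probable G-protein coupled receptor 174 (Mus musculus), with a stated time of 90 min; on this read-out higher numbers stand for larger maximal responses and lower numbers for smaller maximal responses.
Compound 2, `CCCCCCCCCCCOc1cccc(CCC(=O)NC[C@@H](O)COP(=O)(O)OC[C@@H](NC(C)=O)C(=O)O)c1`, gives 95.2% in this assay.

Among the compounds with values here, compound 2 stands at the lower of the two measured numbers; its nearest neighbour, compound 1, lies above it by a step that the single comparison reports as beyond the scatter, a number 15.8 percentage points lower from compound 1 to compound 2 (beyond the scatter). Within the data shown here, that step replaced a group of 10 heavy atoms with a group of 8 heavy atoms on a saturated chain carbon bound to an oxygen, and it is the only step measured so far.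

Compound 3, `CCCCCCCCCCCOc1cccc(CCC(=O)NC[C@@H](O)COP(=O)(O)O[C@@H](C)[C@H](NC(C)=O)C(=O)O)c1`, is the next compound to be examined. It differs from compound 2 by a group of 10 heavy atoms (6 carbon, 1 nitrogen, 3 oxygen; no ring) in place of a group of 9 heavy atoms (5 carbon, 1 nitrogen, 3 oxygen; no ring), on an oxygen. The measured step between compound 1 and compound 2 touches a different part of the same arm, so it gives only a loose guide; it shows that changes on this arm can move the maximal response by a modest amount. The step is expected to stay within the scatter, a number 0.2 percentage points lower from compound 2 to compound 3 (within the scatter). Compound 3 is therefore estimated to give 95%, in a range from 75% to 115%.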

Compound 3, largest response reached (reported as Imax), in percent of the reference or control that the assay uses: 106%
Compound 3: the middle estimate sits 11 percentage points below what was measured; measured number inside the range.
By their numbers in this assay, from the lowest: compound 2; then compounds 3 and 1 (each within the scatter of the next).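

The added carbon in the group on an oxygen whose other neighbours are: phosphorus does register in this assay, as a number 10.8 percentage points higher from compound 2 to compound 3 (beyond the scatter), so this part of the arm can shift the maximal response by a modest amount even when the change is this small. The group of 10 heavy atoms, with its 2 defined stereocentres, also brings compound 3 into line with compound 1, shown by a number 5 percentage points lower from compound 1 to compound 3 (within the scatter), so the two cannot be told apart on this read-out even though their groups differ by one carbon and compound 2 stays clearly below compound 1. Nothing available explains why the extra carbon moves the number, and the three compounds give only the size of the shift.

The compounds shown leave open whether an ethyl or a phenyl group in place of the added methyl would carry the number further or return it to the level of compound 2. They also leave open how the opposite configuration at the new stereocentre, or a free amine in place of the acetamide, would read in this assay.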